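The source may report more compounds than this note shows. Statements on the series, on what has been measured and on what is new or still open speak of the compounds shown alone.

Working notes on the series. All members share one core carrying a variable group on an aromatic carbon. Compound 1 is `Cc1cc(Cc2cccc(F)c2)c(=O)n(CC(=O)Nc2ccc(Br)cc2)n1` and compound 2 is `Cc1cc(N)c(=O)n(CC(=O)Nc2ccc(Br)cc2)n1`. In an assay on HL-60 cells for agonist activity at N-formyl peptide receptor 3 (Homo sapiens), read by calcium flux (a higher number here means that more compound is needed for the effect, a lower number that less compound is needed), compound 1 reaches only a limit, > 50000 nM. In this assay compound 2 likewise reaches only a limit, > 50000 nM. The step that the two limits leave unreadable from compound 1 to compound 2 therefore cannot be sized, since the limit of > 50000 nM in this assay, at which 2 of the 2 values shown sit, is where both values sit. On the numbers shown, compound 2 thus stands at the limit and has no number of its own.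

The next compound, compound 3, is `COc1ccc(-c2cc(C)nn(CC(=O)Nc3ccc(Br)cc3)c2=O)cc1`. The change from compound 2 is 4-methoxyphenyl in place of amino on an aromatic carbon. Among the compounds with values here, the single measured step, from compound 1 to compound 2, bears on this change only in that both of its ends sit at the limit, so neither its size nor its direction in this assay can be read, and no measured step fixes what the new group should do.

For compound 3 the expected value in this assay is 70000 nM, with a range of 15000 nM to 300000 nM, most likely again reported as a limit rather than a number. The expected step is accordingly a step that the limit leaves unreadable from compound 2 to compound 3, with no direction beyond the scatter claimed.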

Compound 3, half-maximal effective concentration: > 50000 nM
Compound 3 was reported as a limit; the forecaster's own chance of this, stated with the estimate: 75%; the middle value does not contradict the limit.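

Within the data shown here, compound 3 also reaches only a limit in this assay, so no step among compound 1, compound 2 and compound 3 can be read: the limit of > 50000 nM in this assay, at which 3 of the 3 values shown sit. The compounds shown leave open whether any group on this aromatic carbon of the shared core gives a measurable value in this assay, and in which direction any of these changes acts.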